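The source may report more compounds than this note shows. Statements on the series, on what has been measured and on what is new or still open speak of the compounds shown alone.

Compound 2 `Fc1ccc(Nc2cncc(N3CC4CC(C3)N4)c2)cc1` gives 1.25 nM in an assay on HEK293 cells for displacement of a labelled ligand from Neuronal acetylcholine receptor; alpha3/beta4 (Homo sapiens) (a higher number here means a weaker inhibitor, a lower number a stronger inhibitor), the higher of the two numbers measured, though compound 1 `Clc1ccc(Nc2cncc(N3CC4CC(C3)N4)c2)cc1` with 1.2 nM stands within the scatter of it, as the step of a 1.0-fold higher number from compound 1 to compound 2 (0.02 log units; within the scatter) shows. The next step, to compound 3 `c1ccc(Nc2cncc(N3CC4CC(C3)N4)c2)cc1`, is hydrogen in place of fluoro on an aromatic carbon: 4-fluorophenyl becomes phenyl. Only the halogen swap from compound 1 to compound 2 bears on this, and it left this assay unchanged, so no large shift is expected; losing the halogen altogether is not itself shown, and a modest weakening is guessed. Compound 3 is therefore expected to give 2.5 nM (range 0.7 nM to 9 nM), a step of a 2.0-fold higher number from compound 2 to compound 3 (0.30 log units; within the scatter).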

Compound 3, inhibition constant: 0.799 nM
Estimate against measurement, compound 3: 3.1-fold (0.50 log units) above, and the stated range covers the measured number.
By their numbers in this assay, from the lowest: compounds 3, 1 and 2 (each within the scatter of the next).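

Hydrogen, fluoro and chloro cannot be told apart at this place on the phenyl ring in this assay, as the halogen can be removed altogether with the result staying within the scatter (a 1.6-fold lower number from compound 2 to compound 3 (0.19 log units; within the scatter); a 1.5-fold lower number from compound 1 to compound 3 (0.18 log units; within the scatter)). The earlier pair showed only one halogen exchanged for another, whereas compound 3 shows that no halogen is needed at this place to stay in this range. Nothing available explains this result.

On these data alone, it remains open whether a methoxy group, an amine or a carboxylic acid at this place would also stay within the scatter of these three compounds.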